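The source may hold more compounds than are shown below. What is called first, only, known or untested is meant among the compounds shown, and "the series" means these compounds.

In a functional assay on HBL-100 cells (Homo sapiens) for antiproliferative activity, read by sulforhodamine B assay, with a stated time of 48 h (on this read-out higher numbers stand for weaker inhibition of growth and lower numbers for stronger inhibition of growth), three compounds have been measured so far:
compound 1, `CCCCCCCCC[C@@H](O)[C@H](C)N`, gives 6600 nM;
compound 2, `CCCCCCCCC[C@@H](O)[C@@H](N)[C@@H](C)CC`, gives 13000 nM;
compound 3, `CCCCCCCCCCCCCCC[C@@H](O)[C@H](C)N`, gives 2300 nM.

Compound 3 has the lowest number of the three. Its core differs from that of compound 1 by hexyl in place of hydrogen on a saturated chain carbon, ten or more bonds along the chain from an oxygen on a saturated carbon, a change that gave a 2.9-fold lower number from compound 1 to compound 3 (0.46 log units; beyond the scatter). The change from compound 1 to compound 2 is sec-butyl in place of methyl on a saturated chain carbon bound to an amine nitrogen and a saturated chain carbon, and it gave a 2.0-fold higher number from compound 1 to compound 2 (0.29 log units; within the scatter). Compound 4, `CCCCCCCCCCCCCCC[C@@H](O)[C@@H](N)[C@@H](C)CC`, has not yet been measured; it differs from compound 3 by sec-butyl in place of methyl on a saturated chain carbon bound to an amine nitrogen and a saturated chain carbon, the same change made on the core of compound 3. For the measured compounds named here, a step of similar size is expected from compound 3 to compound 4, namely a 2.0-fold higher number from compound 3 to compound 4 (0.30 log units; within the scatter) in this assay, because a 2.0-fold higher number from compound 1 to compound 2 (0.29 log units; within the scatter) is the only earlier example of this change. Compound 4 is therefore estimated at 4600 nM in this assay, with a likely range from 2000 nM to 11000 nM.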

Compound 4, concentration for 50% growth inhibition: 2400 nM
Compound 4: the middle estimate sits 1.9-fold (0.28 log units) above what was measured; the range from low to high includes it.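

In this assay, sec-butyl in place of methyl gave a 1.0-fold higher number from compound 3 to compound 4 (0.02 log units; within the scatter), and this step agrees with the earlier one on the other core: the same change on two cores in this assay, a 2.0-fold higher number (0.29 log units; within the scatter) from compound 1 to compound 2 and a 1.0-fold higher number (0.02 log units; within the scatter) from compound 3 to compound 4, 1.9-fold (0.28 log units) apart, within the scatter of two such steps. Adding hexyl gave a 5.4-fold lower number from compound 2 to compound 4 (0.73 log units; beyond the scatter), and this change also carried over from one core to the other: the same change on two cores in this assay, a 2.9-fold lower number (0.46 log units; beyond the scatter) from compound 1 to compound 3 and a 5.4-fold lower number (0.73 log units; beyond the scatter) from compound 2 to compound 4, 1.9-fold (0.28 log units) apart, within the scatter of two such steps. For the compounds shown here, with only two pairs of compounds for each change, this shows that the steps agree on these two cores, but it does not show that they would carry over to any other core or assay.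

On these data alone, it remains open how a longer chain, or a carboxylic acid in place of the amine, would behave. As far as these compounds go, it is also open whether the sec-butyl and hexyl steps would hold beside either change.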